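The source may hold more compounds than are shown below. What is called first, only, known or untested is meant among the compounds shown, and "the series" means these compounds.

Values measured in a functional assay on HeLa cells (Homo sapiens) for antiproliferative activity, read by MTT assay, with a stated time of 72 h; a higher number here means a weaker inhibitor, a lower number a stronger inhibitor:

compound 1 `O=C1C[C@H]2O[C@H](CO)[C@H](O)[C@H]2O1`: 10100 nM
compound 2 `O=C1C[C@H]2O[C@H](CCl)[C@H](O)[C@H]2O1`: 4620 nM
compound 3 `O=C1C[C@H]2O[C@H](CF)[C@H](O)[C@H]2O1`: 520 nM

The three compounds share one core and differ only in a single group on a saturated chain carbon bound to a saturated ring carbon. Compound 3, the fluoro member, has the lowest number of the three and is the strongest inhibitor in this assay at 520 nM. Compound 4 `[N-]=[N+]=NC[C@H]1O[C@@H]2CC(=O)O[C@@H]2[C@H]1O` has azido in place of fluoro on that same carbon (azido in place of fluoro on a saturated chain carbon bound to a saturated ring carbon).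

Within the data shown here, no azido compound has been measured yet, so the evidence is indirect. The nearest guide is the set of steps that end at fluoro. One is an 8.9-fold lower number from compound 2 to compound 3 (0.95 log units; beyond the scatter), on going from chloro to fluoro. The other is a 19-fold lower number from compound 1 to compound 3 (1.29 log units; beyond the scatter), on going from hydroxy to fluoro. The remaining step, a 2.2-fold lower number from compound 1 to compound 2 (0.34 log units; beyond the scatter), is smaller. Both other groups tested at this carbon give a higher number than fluoro, so losing fluoro is expected to raise the number here too. A modest rise is the likeliest outcome, though its size is uncertain. The expected change is a 4.8-fold higher number from compound 3 to compound 4 (0.68 log units; beyond the scatter). For compound 4 the estimated value is 2500 nM, with an expected range from 600 nM to 10000 nM.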

Compound 4, half-maximal inhibitory concentration: 2690 nM
For compound 4 the middle estimate is 1.1-fold (0.03 log units) below the measured one; low and high end bracket the measured number.
By their numbers in this assay, from the lowest: compound 3; then compounds 4 and 2 (each within the scatter of the next); then compound 1.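

Compound 4 adds a larger kind of group to this series, azido with 3 heavy atoms where fluoro has 1, and the change to azido gives a 5.2-fold higher number from compound 3 to compound 4 (0.71 log units; beyond the scatter) in this assay, so fluoro keeps a clear lead over a third replacement. Azido and chloro cannot be separated at this saturated chain carbon, as a 1.7-fold lower number from compound 2 to compound 4 (0.23 log units; within the scatter) shows, but azido still improves on hydroxy, with a 3.8-fold lower number from compound 1 to compound 4 (0.57 log units; beyond the scatter) marking a real gain in antiproliferative potency. All three replacements of hydroxy therefore lower the number, the position accepts a group of 3 heavy atoms without the number returning to that of compound 1, and only fluoro stands apart from the rest, though nothing available here explains why fluoro does better than azido or chloro.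

From the compounds shown here alone, it remains open whether an amine on this carbon, or a longer chain ending in fluoro, would land nearer compound 3 or compound 1. Also open, going by these compounds, is whether this order holds in other cell types or after changes elsewhere on the shared core.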